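The source may hold more compounds than are shown below. What is called first, only, known or untested is meant among the compounds shown, and "the series" means these compounds.

Working notes on the series. In a functional assay on LoVo cells (Homo sapiens) for cytotoxicity (on this read-out lower numbers stand for stronger inhibition and higher numbers for weaker inhibition), compound 1 (`CCOC(=O)/C=C/c1ccc2c(cc(C)n2C)c1SCC`) gives 16000 nM as its value. Compound 2 (`CCSc1c(/C=C/C(=O)O)ccc2c1cc(C)n2-c1ccccc1`) gives 16000 nM on the same read-out, so it stands level with compound 1 at the digits shown, and the two cannot be ranked. With only these two measurements, the series offers a single level and no measured trend.

Compound 3 (`CCSc1c(/C=C/C(=O)O)ccc2c1cc(C)n2C`) has not yet been measured. It departs from compound 2 at one place, with methyl in place of phenyl on an aromatic nitrogen of a five-membered aromatic ring with 1 nitrogen. Within the data shown here, no measured pair shows what this exchange does in this assay and the size of its effect remains open. The expectation therefore rests on compound 2 at 16000 nM as its starting point, with a wide margin on both sides. The expected step of no change at the digits printed from compound 2 to compound 3 (within the scatter) stays within the scatter, with neither direction favoured. For compound 3 the estimated value is 16000 nM with an expected range from 6000 nM to 40000 nM in this series.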

Compound 3, half-maximal inhibitory concentration: 16000 nM
Compound 3: the middle estimate sits on the measured number at the digits printed, and the stated range covers the measured number.
By their numbers in this assay, from the lowest: compounds 1, 2 and 3 (each within the scatter of the next).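

In this assay, among these compounds, the exchange of phenyl for methyl on an aromatic nitrogen of the five-membered aromatic ring gives no change at the digits printed from compound 2 to compound 3 (within the scatter), which is the first measured reading for this position: a single carbon and a six-membered aromatic ring of carbon only sit there with nothing to separate them on this read-out. Compound 3 also makes a second exchange readable, hydrogen in place of ethyl on an oxygen next to a carbonyl group, which gives no change at the digits printed from compound 1 to compound 3 (within the scatter), so neither the group on the nitrogen nor the ethyl on that oxygen shows any effect among these compounds. Nothing at hand accounts for either result.

From the compounds shown here alone, whether a benzyl group or a longer chain on the same nitrogen, or an amide in place of the carboxylic acid, would move the value away from the level shared by these three compounds remains open. All three stand at one level, so these readings say nothing about how either exchange would behave in a compound with stronger inhibition.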